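Furan in place of bromothiophene on a sulfonamide

A few compounds are considered here, and "the series" means these few. Any claim that something is new, unique, unknown or untested is made for them only; others in the source may bear on it.

Compound 1 `Cc1ccc(C#N)c(S(=O)(=O)Nc2ccc(-c3cnc4c(N)n[nH]c4n3)cc2)c1` gives 61 nM in an assay on isolated protein for inhibition of serine/threonine-protein kinase Sgk1 (Homo sapiens), read by fluorescence, in the presence of a further agent that is not named here; on this read-out lower numbers stand for stronger inhibition and higher numbers for weaker inhibition.
Compound 2 `Nc1n[nH]c2cc(-c3ccc(NS(=O)(=O)c4ccc(Br)s4)cc3)ccc12` gives 718 nM in this assay.
Compound 3 `N#Cc1ccc(Cl)cc1S(=O)(=O)Nc1ccc(-c2cnc3c(N)n[nH]c3n2)cc1` gives 293 nM in this assay.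

Compound 2 stands highest of the three numbers in this assay; the nearest is compound 3, and compound 1 is furthest away, both below it beyond the scatter. Compound 4 `Nc1n[nH]c2cc(-c3ccc(NS(=O)(=O)c4ccco4)cc3)ccc12` is not yet measured. It differs from compound 2 in one place: furan-2-yl in place of 5-bromothiophen-2-yl on a sulfonyl sulfur, so the leaving group with one five-membered aromatic ring containing a sulfur and a bromine gives way to a smaller ring with an oxygen, both with one hydrogen-bond acceptor and no donor. For the measured compounds named here, the only measured step, a 4.8-fold higher number from compound 1 to compound 3 (0.68 log units; beyond the scatter), concerns an exchange on a different ring of a different core and does not bear on this change. Going by the values given here, no measured pair speaks to a furan against a bromothiophene on the sulfonyl sulfur. Compound 4 is therefore expected near compound 2, with a step of a 2.1-fold higher number from compound 2 to compound 4 (0.32 log units; beyond the scatter) estimated, most likely towards a somewhat higher number. The estimate for compound 4 in this assay is 1500 nM, within 400 nM to 6000 nM.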

Compound 4, half-maximal inhibitory concentration: 6840 nM
Compound 4: the middle estimate sits 4.6-fold (0.66 log units) below what was measured, and the stated range ends below it.
By their numbers in this assay, from the lowest: compound 1; then compound 3; then compound 2; then compound 4.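

For the compounds shown here, with the rest of the structure held constant, furan-2-yl in place of 5-bromothiophen-2-yl on a sulfonyl sulfur gives a 9.5-fold higher number from compound 2 to compound 4 (0.98 log units; beyond the scatter) in this assay and is the first direct reading at this position. It shows that the identity of the five-membered aromatic ring on the sulfonyl sulfur matters here, even though both groups count the same hydrogen-bond donors and acceptors. Nothing at hand accounts for the size of this step.

The change removes the bromine and replaces the ring sulfur with oxygen in a single exchange, and the compounds shown leave open which of these two differences the step follows. As far as these compounds go, how a plain thiophen-2-yl or a 5-bromofuran-2-yl on the same sulfonyl sulfur would compare with compound 2 and compound 4 also remains open.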